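Compound 1 as the sole anchor for compound 3

The source may hold more compounds than are shown below. What is called first, only, known or untested is meant among the compounds shown, and "the series" means these compounds.

- compound 1 `COC1=C(C)C(=O)/C(=C(O)/C=C/c2ccc(O)cc2)C(=O)C1(C)C` gives 3.8 ug/mL in a functional assay on HUVEC cells (Homo sapiens) for cytotoxicity; a higher number here means that more compound is needed for the effect, a lower number that less compound is needed
- compound 2 `CCc1ccc(/C=C/C(O)=C2/C(=O)C(C)=C(OC)C(C)(C)C2=O)cc1` gives "not determined" (no result reported) in this assay

Within the data shown here, compound 1 holds the only number so far, and compound 2 has no result to compare it with. Compound 3 `COC1=C(C)C(=O)/C(=C(O)/C=C/c2cc(C)cc(C)c2)C(=O)C1(C)C` keeps the core of compound 1 and carries 3,5-dimethylphenyl in place of 4-hydroxyphenyl on a double-bonded chain carbon bound to a double-bonded chain carbon on a double-bonded chain carbon bound to a double-bonded chain carbon. Among the measured compounds shown here, no measured pair shows the effect of such a change, so no step beyond the scatter is expected in this assay and no direction can be supported. The estimated size is a 1.2-fold higher number from compound 1 to compound 3 (0.07 log units; within the scatter) and no more. For compound 3 the estimate is 4.5 ug/mL with 1.5 ug/mL to 14 ug/mL as the expected range.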

Compound 3, concentration for half-maximal effect: 2.5 ug/mL
Compound 3: the middle estimate sits 1.8-fold (0.26 log units) above what was measured; the range from low to high includes it.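

Among these compounds, the first readable step, 3,5-dimethylphenyl in place of 4-hydroxyphenyl on a double-bonded chain carbon bound to a double-bonded chain carbon, stays within the scatter in this assay (a 1.5-fold lower number from compound 1 to compound 3 (0.18 log units; within the scatter)). In this one pair, the hydrogen-bond donor and acceptor counted on 4-hydroxyphenyl can therefore go without a change beyond the scatter. Nothing further is available to explain this result.

Going by these compounds, whether the same holds for a group carrying an amine or a carboxylic acid in place of 4-hydroxyphenyl stays open. On these data alone, the shared core also remains untested by any readable step.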